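Cyclohexyl for methyl on the ring amide nitrogen

The source may report more compounds than this note shows. Statements on the series, on what has been measured and on what is new or still open speak of the compounds shown alone.

Of the compounds shown here, three sharing one core have been measured in an assay on HEK293 cells for displacement of a labelled ligand from metabotropic glutamate receptor 5 (Homo sapiens), with a stated time of 2 h; a lower number here means a stronger inhibitor, a higher number a weaker inhibitor. Compound 1 `Cc1cccc(C#Cc2ccc3c(n2)CCN(C)C3=O)c1` gives 820 nM. Compound 2 `CN1CCc2nc(C#Cc3cccc(Cl)c3)ccc2C1=O` gives 250 nM, and compound 3 `CN1CCc2nc(C#Cc3cccnc3)ccc2C1=O` gives 27400 nM. Compound 1 therefore stands second highest of the three numbers: the step of a 3.3-fold lower number from compound 1 to compound 2 (0.52 log units; beyond the scatter) is modest, while the step of a 33-fold higher number from compound 1 to compound 3 (1.52 log units; beyond the scatter) is large, and the step of a 110-fold higher number from compound 2 to compound 3 (2.04 log units; beyond the scatter) is larger still.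

Compound 4 `Cc1cccc(C#Cc2ccc3c(n2)CCN(C2CCCCC2)C3=O)c1` has not yet been measured. It differs from compound 1 in one place: cyclohexyl in place of methyl on an amide-type nitrogen in a ring. Going by the values given here, none of the measured steps touches this position. Each of them alters the aryl group on the triple-bonded carbon, and they leave the amide-type nitrogen untouched. Among the compounds with values here, they show that this assay responds strongly to the aryl group, but they say nothing about the nitrogen substituent, so the step to compound 4 rests on no measured precedent.

Within the data shown here, with no step bearing on it, the expectation for compound 4 is a change no larger than modest in either direction, most likely none beyond the scatter, so that the estimated step is a 1.2-fold higher number from compound 1 to compound 4 (0.09 log units; within the scatter). Compound 4 is estimated at 1000 nM, within a range from 250 nM to 4000 nM.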

Compound 4, inhibition constant: 3210 nM
Beside the measured number, compound 4's estimate is 3.2-fold (0.51 log units) below it, within the range that was stated.
By their numbers in this assay, from the lowest: compound 2; then compound 1; then compound 4; then compound 3.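

The amide-type nitrogen in a ring proves to be a position that this assay can read: cyclohexyl in place of methyl gives a 3.9-fold higher number from compound 1 to compound 4 (0.59 log units; beyond the scatter), so the number responds to this substituent as well as to the aryl group on the triple-bonded carbon. In size, the step remains modest and smaller than the large change at the aryl group, a 33-fold higher number from compound 1 to compound 3 (1.52 log units; beyond the scatter), so replacing methyl with the much larger cyclohexyl moves the number less than replacing 3-methylphenyl with pyridin-3-yl does. Nothing in the available data accounts for the direction or size of this step.

With only methyl and cyclohexyl shown on this nitrogen, the compounds do not separate the effect of the ring from that of the added carbons, and it remains open how an ethyl group, a straight hexyl chain, a phenyl ring or a chain ending in an amine would compare. Also open, going by these compounds, is whether the step from methyl to cyclohexyl would be of similar size with 3-chlorophenyl or pyridin-3-yl on the triple-bonded carbon.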